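Halogenated versus methoxy aryl on the benzylidene of the series

The compounds below may be only part of what the source reports. "The series", "measured", "known", "first", "only" and "open" are said of these compounds alone.

Within the data shown here, compound 2 `C=CCn1c(=O)/c(=C\c2cc(Br)ccc2F)[nH]c(=O)/c1=C\c1ccccc1OC` gives 12900 nM in a functional assay on MOLT-4 cells (Homo sapiens) for cytotoxicity, read by CCK-8 assay, with a stated time of 72 h (on this read-out lower numbers stand for stronger inhibition and higher numbers for weaker inhibition), which is the higher of the two numbers measured so far; the nearest compound is compound 1 `C=CCn1c(=O)/c(=C\c2cccc(Cl)c2Cl)[nH]c(=O)/c1=C\c1ccccc1OC`, which in this assay gives 1200 nM. Among the measured compounds shown here, the single measured step, an 11-fold higher number from compound 1 to compound 2 (1.03 log units; beyond the scatter), shows that exchanging one halogenated phenyl for another on a double-bonded chain carbon bound to an aromatic carbon shifts the number a long way. Compound 3 `C=CCn1c(=O)/c(=C\c2ccccc2OC)[nH]c(=O)/c1=C\c1ccccc1OC` is the next compound in line; its change is 2-methoxyphenyl in place of 5-bromo-2-fluorophenyl on a double-bonded chain carbon bound to an aromatic carbon. For the measured compounds named here, no measured step covers a halogenated phenyl giving way to a methoxyphenyl at this place, so the direction is uncertain and only the width of the measured step offers a scale. The expectation for compound 3 is therefore a number between the two known values, with compound 3 estimated at 6000 nM (range 1500 nM to 25000 nM). That estimate corresponds to an expected step of a 2.2-fold lower number from compound 2 to compound 3 (0.33 log units; beyond the scatter).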

Compound 3, half-maximal inhibitory concentration: 13100 nM
The estimate for compound 3 lay 2.2-fold (0.34 log units) below the measured number, within the range that was stated.
By their numbers in this assay, from the lowest: compound 1; then compounds 2 and 3 (each within the scatter of the next).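

In this assay the step to the 2-methoxyphenyl group, a 1.0-fold higher number from compound 2 to compound 3 (0.01 log units; within the scatter), leaves the two compounds level, so halogens on the phenyl do not by themselves set the number at this place: compound 2 carries two halogens and compound 3 none. Against the 2,3-dichlorophenyl group the same 2-methoxyphenyl group gives an 11-fold higher number from compound 1 to compound 3 (1.04 log units; beyond the scatter), so among these three compounds only the 2,3-dichlorophenyl group of compound 1 goes with a lower number. No measurement at hand explains why compound 1 stands apart.

Open, as far as these compounds go, is whether that lower number needs both chlorines, which 2-chlorophenyl and 3-chlorophenyl groups would test. Also open, from the compounds shown here alone, is how a phenyl bearing an amine or a carboxylic acid would read at this place.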